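Swapping benzyl for thiophen-2-yl on compound 3

The compounds below may be only part of what the source reports. "The series", "measured", "known", "first", "only" and "open" are said of these compounds alone.

- compound 1 `CN(CC(N)=O)Cc1ccc(OCc2cccc(Cl)c2)cc1`: 114 mg/kg
- compound 2 `C[C@@H](NCc1ccc(Cc2ccccc2)cc1)C(N)=O`: 15.7 mg/kg
- compound 3 `C[C@@H](NCc1ccc(OCCc2ccccc2)cc1)C(N)=O`: 24.9 mg/kg

These three compounds were tested in a functional assay on the whole organism with Mus musculus as the target; a lower number here means that less compound is needed, a higher number that more compound is needed for the effect. Compound 3 at 24.9 mg/kg lies within the scatter of compound 2 at 15.7 mg/kg. Compared with compound 1 at 114 mg/kg, compound 3 needs clearly less compound, a gap beyond the scatter.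

The next compound to be tested is compound 4 `C[C@@H](NCc1ccc(OCc2cccs2)cc1)C(N)=O`. It has thiophen-2-yl in place of benzyl on a saturated chain carbon bound to an oxygen on an aromatic ring. Among the compounds with values here, no two measured compounds differ in one place only, so the data give no direct guide to this change. The closeness of compound 2 at 15.7 mg/kg and compound 3 at 24.9 mg/kg offers only weak support for expecting no step beyond the scatter in this assay. The expected change is a 1.1-fold lower number from compound 3 to compound 4 (0.03 log units; within the scatter). For compound 4 the estimated value is 23 mg/kg, with an expected range of 10 mg/kg to 55 mg/kg.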

Compound 4, dose for half-maximal effect: 61.6 mg/kg
Compound 4: middle estimate off by 2.7-fold (0.43 log units), on the low side; measured number outside the range, above it.
By their numbers in this assay, from the lowest: compounds 2 and 3 (each within the scatter of the next); then compounds 4 and 1 (each within the scatter of the next).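

In this assay, replacing benzyl with thiophen-2-yl on a saturated chain carbon bound to an oxygen on an aromatic ring gives a 2.5-fold higher number from compound 3 to compound 4 (0.39 log units; beyond the scatter) and so shows that this position responds to the group it carries. Within the data shown here, this is the first direct reading of a change at this place, and here the six-membered aromatic ring of carbon only gives way to a five-membered aromatic ring with 1 hetero atom, with 5 heavy atoms entering where 7 leave. No measured evidence on any property of these compounds accounts for the step.

A single pair cannot separate the change of ring from the change in the number of heavy atoms. On these data alone, it remains open how furan-2-yl, or thiophen-2-yl carried on a longer chain, would behave at this place.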